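This account rests on a few compounds, and the source may have more. Where it says the series, first, only, none or still open, it means among the compounds named here.

Compound 3 `CC[C@H](C)[C@H](NC(=O)CN(c1nc(Cl)nc2[nH]cnc12)C1CC1)C(=O)OCc1ccccc1` stands second highest of the three measured compounds in a functional assay on the whole organism (Tail, strain ICR) with Mus musculus as the target, in the tail flick test, with a stated time of 60 min, at a dose of 25 umol/kg by the oral route; on this read-out higher numbers stand for a stronger effect at the one dose given and lower numbers for a weaker effect. Compound 3 gives 40.6%, while compound 1 `C[C@H](NC(=O)CN(c1nc(Cl)nc2[nH]cnc12)C1CC1)C(=O)OCc1ccccc1` gives 64.3% and compound 2 `O=C(CN(c1nc(Cl)nc2[nH]cnc12)C1CC1)N[C@@H](CC(=O)OCc1ccccc1)C(=O)OCc1ccccc1` gives 22.4%. The measured steps are a number 23.7 percentage points lower from compound 1 to compound 3 (beyond the scatter) and a number 18.2 percentage points higher from compound 2 to compound 3 (beyond the scatter), so that among these three the side chain on the saturated chain carbon bound to the amide-type nitrogen and the carbonyl carbon matters, and a chain carrying a carbonyl group at that place went with the lowest number. Compound 4 `NC(=O)C[C@H](NC(=O)CN(c1nc(Cl)nc2[nH]cnc12)C1CC1)C(=O)OCc1ccccc1` differs from compound 3 as follows: carbamoylmethyl in place of sec-butyl on a saturated chain carbon bound to an amide-type nitrogen and a carbonyl carbon. Among the compounds with values here, the step that bears most on this change is the reverse of the one from compound 2 to compound 3, since a carbonyl-bearing two-carbon chain again enters in place of sec-butyl. A modest fall beyond the scatter is therefore expected, and the step is estimated as a number 12.6 percentage points lower from compound 3 to compound 4 (beyond the scatter). Compound 4 is expected to give about 28% in this assay, with a range from 12% to 48%.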

Compound 4, a percentage reported as activity, at one dose (the size of the read-out at that dose, not a potency): 36.4%
Compound 4: middle estimate off by 8.4 percentage points, on the low side; the range from low to high includes it.
By their numbers in this assay, from the lowest: compound 2; then compounds 4 and 3 (each within the scatter of the next); then compound 1.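

In this assay, carbamoylmethyl in place of sec-butyl gives a number 4.2 percentage points lower from compound 3 to compound 4 (within the scatter) and so, at this saturated chain carbon, a chain carrying a carbonyl group does not by itself go with a low number. Amino in place of benzyloxy on a carbonyl carbon gives a number 14 percentage points higher from compound 2 to compound 4 (beyond the scatter) and thus ties the low number of compound 2 to the end of that chain, while carbamoyl in place of hydrogen gives a number 27.9 percentage points lower from compound 1 to compound 4 (beyond the scatter) and leaves compound 1, with its small methyl chain, clearly apart. No evidence given here accounts for these steps.

On these data alone, it remains open how a carboxylic acid or an amine at the end of this chain would read. Also open, as far as these compounds go, is whether a longer chain such as carbamoylethyl, or a plain ethyl group, would follow compound 4 or compound 1.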